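The source may report more compounds than this note shows. Statements on the series, on what has been measured and on what is new or still open speak of the compounds shown alone.

Measured compounds:
compound 1, `COc1cc(C2=NOC(c3c[nH]c4ccccc34)C2)cc(OC)c1OC`: 5000 nM
compound 2, `Clc1ccc(Cn2cc(C3CC(c4ccncc4)=NO3)c3ccccc32)cc1`: 11400 nM

Of the compounds shown here, two sharing the isoxazoline core have been measured in a functional assay on LNCaP C4-2 cells (Homo sapiens) for inhibition, read by MTT assay, with a stated time of 48 h; a higher number here means a weaker inhibitor, a lower number a stronger inhibitor. Compound 1, `COc1cc(C2=NOC(c3c[nH]c4ccccc34)C2)cc(OC)c1OC`, gives 5000 nM in this assay. Compound 2, `Clc1ccc(Cn2cc(C3CC(c4ccncc4)=NO3)c3ccccc32)cc1`, gives 11400 nM in this assay. Of the two numbers, compound 2 holds the higher one, and its gap to compound 1 lies beyond the usual scatter, so compound 2 is the weaker inhibitor of the pair. The two differ at several places at once, so no single change can be read off from their gap.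

The next compound, compound 3, `COc1ccc2c(c1)c(C1CC(c3ccncc3)=NO1)cn2Cc1ccc(Cl)cc1`, differs from compound 2 in one place: methoxy in place of hydrogen on an aromatic carbon. Among the measured compounds shown here, no step between measured compounds shows what a change of this kind does in this assay, so the expectation rests on compound 2 alone. A change of a single small group, in the absence of any guiding step, is expected to move the number little, so the step of a 1.3-fold lower number from compound 2 to compound 3 (0.10 log units; within the scatter) is expected to stay within the scatter, with no direction favoured. For compound 3 the estimate in this assay is 9000 nM, in a range from 3000 nM to 27000 nM.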

Compound 3, half-maximal inhibitory concentration: > 100000 nM
Compound 3: only a limit was reported; the forecaster's own chance of this, stated with the estimate: 10%; middle value at least 11-fold (1.04 log units) away from the limit.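

In this assay, among the compounds shown here, this is the first single change that can be read, and placing methoxy in place of hydrogen on this aromatic carbon gives an at least 8.7-fold higher number from compound 2 to compound 3 (0.94 log units; beyond the scatter). The carbon lies on the six-membered aromatic ring of carbon only, meta to a fused ring and para to a fused ring, and the step shows that a change of just this one small group here is enough to carry the number beyond the scatter, towards weaker inhibition. The reading for compound 3 is a limit and not a number, so the step gives only a lower bound on the size of the change: the limit of > 100000 nM in this assay, at which 1 of the 3 values shown sits.

The compounds shown leave open whether this step belongs to methoxy in particular or would follow any group on this carbon, such as a fluorine, a chlorine or a hydroxyl, and whether a longer chain such as ethoxy would behave alike. They also leave open whether methoxy on the matching carbon of compound 1, which differs from compound 2 at several other places, would produce a step of the same direction.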